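Methoxy added to a weak thiourea inhibitor

A few compounds are considered here, and "the series" means these few. Any claim that something is new, unique, unknown or untested is made for them only; others in the source may bear on it.

Compound 1 `OCc1ccc(NC(=S)Nc2ccc3[nH]ccc3c2)cc1`: "not active" (no number reported)
Compound 2 `COc1ccc(NC(=S)Nc2ccc3[nH]ccc3c2)cc1`: 36000 nM
Compound 3 `O=C(c1ccccc1)c1ccc(NC(=S)Nc2ccc3[nH]ccc3c2)cc1`: "not active" (no number reported)

Three compounds sharing one core were tested in an ADME assay on cells for inhibition of Amine oxidase [flavin-containing] A (Homo sapiens), read by spectrophotometry; a higher number here means a weaker inhibitor, a lower number a stronger inhibitor. Compound 1 gives "not active" (no number reported) there, with no number behind it. Compound 3 likewise gives "not active" (no number reported) and no number. Within the data shown here, compound 2 is the only one with a number: in this assay compound 2 gives 36000 nM, which places it as a weak inhibitor, the sole point of reference among the three.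

Compound 4 `COc1ccc(NC(=S)Nc2ccc3[nH]ccc3c2)cc1OC` has not been measured. It differs from compound 2 in one place: methoxy in place of hydrogen on an aromatic carbon. Among the measured compounds shown here, no pair of measured compounds shows what such a change does on this core, so there is no measured step to lean on. The expectation is therefore a step from compound 2 to compound 4 of a 1.1-fold higher number from compound 2 to compound 4 (0.05 log units; within the scatter), which is no more than the scatter of repeated measurements. Compound 4 is estimated at 40000 nM, within a range from 15000 nM to 120000 nM, with a fair chance that only "not active" is reported.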

Compound 4, half-maximal inhibitory concentration: "not active" (no number reported)
No number was reported for compound 4; the estimate stays without a comparison.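

In this assay, among these compounds, compound 4 gives "not active" (no number reported) and so no step from compound 2 to compound 4 can be read. Nothing else available bears on this result. From the compounds shown here alone, what a second methoxy does to inhibition on the shared core stays open.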